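This account rests on a few compounds, and the source may have more. Where it says the series, first, only, none or still open, it means among the compounds named here.

Measured in an assay on isolated protein for antagonist activity at RAC-alpha serine/threonine-protein kinase (Homo sapiens), read by surface plasmon resonance, with a stated time of 30 min; on this read-out higher numbers stand for weaker inhibition and lower numbers for stronger inhibition:
compound 1 `N=C(N/C(=N/O)c1nonc1N)c1ccccc1N`: 8610 nM
compound 2 `N=C(N/C(=N/O)c1nonc1N)c1ccccc1`: 7190 nM
compound 3 `N=C(N/C(=N/O)c1nonc1N)c1ccccc1Br`: 16400 nM

Compound 2 carries the lowest of the three numbers, but one of its two steps lies within the scatter (a 1.2-fold lower number from compound 1 to compound 2 (0.08 log units; within the scatter)), and only the other lies beyond it (a 2.3-fold higher number from compound 2 to compound 3 (0.36 log units; beyond the scatter)), so compound 2 cannot be called the most potent of the set. Compound 4 `N=C(N)NC(=N)N/C(=N/O)c1nonc1N` differs from compound 2 by a group of 4 heavy atoms (1 carbon, 3 nitrogen; no ring) in place of a group of 6 heavy atoms (6 carbon; one six-membered aromatic ring of carbon only), on a carbon with a double bond to nitrogen. Among the measured compounds shown here, none of the measured steps bears directly on this change: the three steps seen (a 1.2-fold lower number from compound 1 to compound 2 (0.08 log units; within the scatter), a 1.9-fold higher number from compound 1 to compound 3 (0.28 log units; within the scatter), a 2.3-fold higher number from compound 2 to compound 3 (0.36 log units; beyond the scatter)) all vary a substituent on the phenyl ring while the ring itself stays, whereas here the ring is removed outright. For the measured compounds named here, those steps were small, so the shared core appears to tolerate changes at this position, but the removal of the ring has no measured precedent. Compound 4 is therefore expected to show a modest rise in this assay, a 1.7-fold higher number from compound 2 to compound 4 (0.22 log units; within the scatter), with wide uncertainty. The estimated value of compound 4 is 12000 nM, expected to fall between 4000 nM and 40000 nM.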

Compound 4, half-maximal inhibitory concentration: 1850 nM
Estimate against measurement, compound 4: 6.5-fold (0.81 log units) above; measured number outside the range, below it.
By their numbers in this assay, from the lowest: compound 4; then compounds 2, 1 and 3 (each within the scatter of the next, the first and the last beyond it).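

In this assay the phenyl group proves dispensable at this place: on the carbon with a double bond to nitrogen, a group with no ring replaces it and gives a 3.9-fold lower number from compound 2 to compound 4 (0.59 log units; beyond the scatter) in the direction of stronger inhibition. The earlier steps shown here only varied a substituent on the phenyl ring, the one beyond the scatter being a 2.3-fold higher number from compound 2 to compound 3 (0.36 log units; beyond the scatter) with weaker inhibition, and so said nothing about losing the ring itself. No measurement given here accounts for the gain.

This single step cannot separate the loss of the phenyl ring from the entry of the nitrogen-rich group. Going by these compounds, it remains open whether a cyclohexyl ring, a methyl group, a plain amine or a longer carbon chain on the same carbon would give a similar number.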